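Chloro for methyl on the pendant aryl ring: second instance

A few compounds are considered here, and "the series" means these few. Any claim that something is new, unique, unknown or untested is made for them only; others in the source may bear on it.

Measured so far in a functional assay on NCI-H226 cells (Homo sapiens) for inhibition, read by MTT assay, with a stated time of 72 h; on this read-out lower numbers stand for stronger inhibition of growth and higher numbers for weaker inhibition of growth:
compound 1 `Cc1ccc(-c2nn(-c3cccc(Cl)c3)c(/N=C/N(C)C)c2C=O)cc1` gives 8900 nM
compound 2 `CN(C)/C=N/c1c(C=O)c(-c2ccc(Cl)cc2)nn1-c1cccc(Cl)c1` gives 9200 nM
compound 3 `Cc1ccc(-c2nn(-c3ccc(Br)cc3)c(N)c2C=O)cc1` gives 8500 nM

Compound 1 and compound 2 differ in one place: chloro in place of methyl on an aromatic carbon. The step of a 1.0-fold higher number from compound 1 to compound 2 (0.01 log units; within the scatter) lies within the scatter of repeated measurements, so the two values show no change in this assay.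

Compound 3 carries a different core; the difference between the core of compound 3 and the core of compound 1 is not broken down here. Its value in this assay sits within the scatter of both compound 1 and compound 2, so no order among the three is read.

Compound 4 `Nc1c(C=O)c(-c2ccc(Cl)cc2)nn1-c1ccc(Br)cc1` is not yet measured. It differs from compound 3 by chloro in place of methyl on an aromatic carbon, the same change as from compound 1 to compound 2, with the place described in identical words. Because the measured step of a 1.0-fold higher number from compound 1 to compound 2 (0.01 log units; within the scatter) was within the scatter, the step from compound 3 to compound 4 is expected to be small as well, a 1.0-fold higher number from compound 3 to compound 4 (0.02 log units; within the scatter).

For compound 4 the estimated value in this assay is 8800 nM, with an expected range from 4500 nM to 17000 nM.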

Compound 4, concentration for 50% growth inhibition: 49100 nM
The estimate for compound 4 lay 5.6-fold (0.75 log units) below the measured number, outside the stated range (above it).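

In this assay, chloro in place of methyl, read as 4-methylphenyl to 4-chlorophenyl, gives a 5.8-fold higher number from compound 3 to compound 4 (0.76 log units; beyond the scatter), so on this core the chloro compound reads as the weaker growth inhibitor, while the same change on the other core gave no step beyond the scatter. The change therefore does not carry over at one size between these two cores: the same change on two cores in this assay, a 1.0-fold higher number (0.01 log units; within the scatter) from compound 1 to compound 2 and a 5.8-fold higher number (0.76 log units; beyond the scatter) from compound 3 to compound 4, 5.6-fold (0.75 log units) apart, beyond the scatter of two such steps. For the compounds shown here, this shows only that two pairs disagree; it gives no rule for the series, and it does not show which feature of the cores goes with the larger step.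

Still open, on these data alone, is whether the larger step goes with the free amino group or with the bromo-substituted aryl ring, both of which compound 3 and compound 4 share. Also open, as far as these compounds go, is how a different group in the same place, such as methoxy or a carboxylic acid, would read on either core.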